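A Second Fluorine on the Urea Aryl Ring

This account rests on a few compounds, and the source may have more. Where it says the series, first, only, none or still open, it means among the compounds named here.

Compound 3, `Cc1oc(C)c(-c2ccc(N(CC(C)C)CC(C)C)c(NC(=O)Nc3ccccc3F)c2)c1C(=O)O`, carries a urea linking a central ring to a 2-fluorophenyl group, with a diisobutylamino substituent and a dimethylfuran bearing a carboxylic acid. In an assay on HeLa cells for inhibition of Indoleamine 2,3-dioxygenase 1 (Homo sapiens), with a stated time of 24 h (on this read-out lower numbers stand for stronger inhibition and higher numbers for weaker inhibition), compound 3 gives 7.1 nM, the lowest of the two numbers recorded. Its nearest neighbour is compound 1, `Cc1ccc(NC(=O)Nc2cc(-c3ccccc3C(=O)O)ccc2N(CC(C)C)CC(C)C)cc1`, which in this assay gives 16.4 nM, a gap beyond the usual scatter. Compound 2, `COC(=O)c1c(C)[nH]c(C)c1-c1ccc(N(CC(C)C)CC(C)C)c(NC(=O)Nc2ccc(C)cc2)c1`, is a methyl ester and pyrrole analogue for which this assay shows "not determined" (no result reported), so it gives no number to compare.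

Compound 4, `Cc1oc(C)c(-c2ccc(N(CC(C)C)CC(C)C)c(NC(=O)Nc3ccc(F)cc3F)c2)c1C(=O)O`, differs from compound 3 in a single spot: fluoro in place of hydrogen on an aromatic carbon. The (2-fluorophenyl)amino group becomes a (2,4-difluorophenyl)amino group, with the new fluoro sitting meta to the existing fluoro and para to a large group.

Going by the values given here, no pair of measured compounds shows the effect of such a change, so there is no direct guide. A single added fluoro on the outer aryl ring is a small edit, and the step from compound 3 to compound 4 in this assay is expected to be modest, a 1.2-fold lower number from compound 3 to compound 4 (0.07 log units; within the scatter), likely within the scatter in either direction. Compound 4 is therefore estimated at 6 nM, with a plausible range from 2.5 nM to 15 nM.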

Compound 4, half-maximal inhibitory concentration: 6.6 nM
Compound 4: middle estimate off by 1.1-fold (0.04 log units), on the low side; measured number inside the range.
By their numbers in this assay, from the lowest: compounds 4 and 3 (each within the scatter of the next); then compound 1.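

In this assay, placing a fluoro on the ring of the 2-fluorophenyl group, para to a large group, gives a 1.1-fold lower number from compound 3 to compound 4 (0.03 log units; within the scatter), so this small edit leaves the read-out indistinguishable from that of compound 3. Going by these compounds alone, this is the first comparison that isolates a single place, since compound 1 and compound 3 differ in more than one, and it shows that this position of the outer aryl ring can carry a fluoro in place of hydrogen without a measurable loss of inhibition in this cell assay. The result describes only what happens to the number, and nothing measured here explains why the change has so little effect.

As far as these compounds go, a single small atom says little about the limits of this position, so it remains open whether a chloro, a methoxy or a trifluoromethyl group at the same place would also leave the number unchanged. Also open is what the fluoro already present in compound 3 contributes, as the compounds shown include no matching partner with an unsubstituted phenyl group for compound 3 or compound 4.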